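The source may report more compounds than this note shows. Statements on the series, on what has been measured and on what is new or still open speak of the compounds shown alone.

Measured compounds in a functional assay on A549 cells (Homo sapiens) for antiproliferative activity, read by MTT assay, with a stated time of 72 h; on this read-out lower numbers stand for stronger inhibition and higher numbers for weaker inhibition:
- compound 1, `Cc1ccccc1NC(=O)C(Cl)Cl`: "not determined" (no result reported)
- compound 2, `Cc1cccc(NC(=O)C(Cl)Cl)c1`: 41100 nM
- compound 3, `O=C(Nc1cccc(Cl)c1)C(Cl)Cl`: 14800 nM

Among the compounds with values here, compound 3 holds the lowest of the two numbers known in this assay; its nearest neighbour is compound 2, reached by the step of a 2.8-fold lower number from compound 2 to compound 3 (0.44 log units; beyond the scatter), which is beyond the scatter though modest. Compound 1 adds nothing to the ranking, as no number was reported for it.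

Compound 4, `N#Cc1cccc(NC(=O)C(Cl)Cl)c1`, differs from compound 3 by cyano in place of chloro on an aromatic carbon. Within the data shown here, no measured pair shows a cyano in place of a chloro, so the only step that speaks to this position at all is the methyl-to-chloro change from compound 2 to compound 3, a modest move. Its size suggests that exchanges at this position shift this read-out by a moderate amount, but its direction cannot be carried over to a different group. The expectation for compound 4 is therefore a step of a 1.2-fold higher number from compound 3 to compound 4 (0.09 log units; within the scatter), essentially within the scatter, leaning slightly toward a higher number. Compound 4 is estimated at 18000 nM, with a range from 6000 nM to 55000 nM.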

Compound 4, half-maximal inhibitory concentration: 66500 nM
Estimate against measurement, compound 4: 3.7-fold (0.57 log units) below; measured number outside the range, above it.
By their numbers in this assay, from the lowest: compound 3; then compounds 2 and 4 (each within the scatter of the next).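

In this assay the position now has a second exchange starting from chloro, a 4.5-fold higher number from compound 3 to compound 4 (0.65 log units; beyond the scatter) and so a modest step, opposite in direction to a 2.8-fold lower number from compound 2 to compound 3 (0.44 log units; beyond the scatter) on the way to chloro. Cyano and methyl are not separated here, with a 1.6-fold higher number from compound 2 to compound 4 (0.21 log units; within the scatter) as their step, so of the three groups on this aromatic carbon only chloro stands apart, with the lowest number. No measurement on hand bears on the reason for this result.

Still open, as far as these compounds go, is how an amine, a carboxylic acid or a methoxy group on the same aromatic carbon would read, and whether chloro would remain apart among them. Compound 1 has no reported result, so the effect of placing the methyl elsewhere on the ring cannot be read.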